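Cyclohexyl-tetrazole anilines: tolerability notes for compound 4

The source may report more compounds than this note shows. Statements on the series, on what has been measured and on what is new or still open speak of the compounds shown alone.

Measured compounds:
- compound 1 `CC1(c2ccc(Nc3nc(N4CCCc5ccccc54)nc(N4CCCc5ccccc54)n3)cc2)NC(=O)c2ccccc2N1`: "not determined" (no result reported)
- compound 2 `CC1(c2ccc(NC(c3ccncc3)c3nnnn3C(C)(C)C)cc2)NC(=O)c2ccccc2N1`: "not determined" (no result reported)
- compound 3 `CC1(c2ccc(NC(c3ccc(Br)cc3)c3nnnn3C3CCCCC3)cc2)NC(=O)c2ccccc2N1`: > 400000 nM

In an ADME assay on J774.A1 cells (Mus musculus) for cytotoxicity, read by MTT assay, with a stated time of 72 h (a lower number here means that less compound is tolerated, a higher number that more compound is tolerated), compound 1 gives "not determined" (no result reported) and compound 2 gives "not determined" (no result reported), so neither contributes a number. Compound 3 gives > 400000 nM, which is a limit of the assay and not a measured number. Compound 3 therefore stands at the one limit recorded in this series, (the limit of > 400000 nM in this assay, at which 1 of the 3 values shown sits), with the two other entries giving nothing to compare against. Among the compounds with values here, no step between measured compounds can be drawn.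

The unmeasured compound 4 `CC(C)c1ccc(C(Nc2ccc(C3(C)NC(=O)c4ccccc4N3)cc2)c2nnnn2C2CCCCC2)cc1` keeps the whole shared core of compound 3 and changes only one place: isopropyl in place of bromo on an aromatic carbon. Nothing in the data attaches any measured effect to this change, and there is no comparison between two numbers anywhere in the set.

With compound 3 sitting at the limit in this assay, the expected step of a number no higher from compound 3 to compound 4 (the limit leaves the size open) is none beyond the scatter. Compound 4 is therefore estimated to be tolerated at 400000 nM in this assay, with the range running from 150000 nM to 800000 nM, and the most likely outcome for compound 4 is again a limit rather than a number.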

Compound 4, half-maximal cytotoxic concentration: > 400000 nM
Compound 4 ended at the assay's limit; the forecaster's own chance of this, stated with the estimate: 70%; the middle value lies on the limit itself.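

In this assay, compound 3 and compound 4 both end at a limit of the assay rather than at a number, so no step can be read between them: the limit of > 400000 nM in this assay, at which 2 of the 4 values shown sit.

The compounds shown leave open where the half-maximal cytotoxic concentration of either compound lies, and whether isopropyl in place of bromo on an aromatic carbon shifts it at all.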